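Swapping hexyl for benzyl on compound 3

The source may hold more compounds than are shown below. What is called first, only, known or untested is meant among the compounds shown, and "the series" means these compounds.

For the measured compounds named here, in an ADME assay on cells (Macrophage) for cytotoxicity, read by resazurin assay, with a stated time of 48 h (a lower number here means that less compound is tolerated, a higher number that more compound is tolerated), compound 1 `Nc1nc(-c2ccc(Cl)cc2)cc(-c2ccc(OCc3cn(Cc4ccccc4)nn3)cc2O)n1` gives 66600 nM, the only number so far. Compound 2 `CC(C)c1ccc(-c2cc(-c3ccc(OCc4cn(Cc5ccc(Br)cc5)nn4)cc3O)nc(N)n2)cc1` stands at "not determined" (no result reported). Compound 3 `CCCCCCn1cc(COc2ccc(-c3cc(-c4ccc(C(C)C)cc4)nc(N)n3)c(O)c2)nn1` also stands at "not determined" (no result reported), so it offers no number to start from. In compound 4 `CC(C)c1ccc(-c2cc(-c3ccc(OCc4cn(Cc5ccccc5)nn4)cc3O)nc(N)n2)cc1`, phenyl takes the place of pentyl on a saturated chain carbon bound to an aromatic nitrogen (phenyl in place of pentyl on a saturated chain carbon bound to an aromatic nitrogen), which turns hexyl into benzyl. Going by the values given here, no measured pair shows what such a change does in this assay, so no step beyond the usual scatter is expected, in either direction. Among the compounds with values here, the expectation therefore leans on compound 1 at 66600 nM, the sole measured value. Compound 4 is estimated at 50000 nM, with an expected range of 20000 nM to 120000 nM.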

Compound 4, half-maximal cytotoxic concentration: > 100000 nM
Compound 4 gave a limit, no number; the forecaster's own chance of this, stated with the estimate: 25%; middle value at least 2.0-fold (0.30 log units) away from the limit.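

In this assay compound 4 gives > 100000 nM, which is a limit of the assay and not a number. Isopropyl in place of chloro on an aromatic carbon brings an at least 1.5-fold higher number from compound 1 to compound 4 (0.17 log units; that floor lies within the scatter), and the real size of this step stays unknown: the limit of > 100000 nM in this assay, at which 1 of the 4 values shown sits. Hexyl to benzyl cannot be read, as compound 3 has no result.

The compounds shown leave open how an amine or a carboxylic acid in place of phenyl on the saturated chain carbon bound to an aromatic nitrogen would fare in this assay.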